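Methoxy in place of iodo: tolerance in the series

This account rests on a few compounds, and the source may have more. Where it says the series, first, only, none or still open, it means among the compounds named here.

Of the compounds shown here, three of the shared core have been measured in an ADME assay on RAW264.7 cells (Mus musculus) for cytotoxicity, read by MTT assay, with a stated time of 18 h; a higher number here means that more compound is tolerated, a lower number that less compound is tolerated. Compound 1 `C=C1C(=O)OC[C@H]1CCOC(=O)Nc1ccc(I)cc1` gives 12800 nM. Compound 2 `C=C1C(=O)OC[C@@H]1CCOC(=O)Nc1ccc(I)cc1` gives 12500 nM, and compound 3 `C=C1C(=O)OC[C@@H]1CCOC(=O)Nc1cccc(Br)c1` gives 17700 nM. The three numbers lie within the scatter of one another, so compound 1 stands with the others rather than apart from them. Among the compounds with values here, the one step that can be read directly, a 1.0-fold lower number from compound 1 to compound 2 (0.01 log units; within the scatter), reflects the fact that compounds 1 and 2 differ only in the configuration as drawn and nothing else; compound 3 differs from compound 1 in more than one place, and its value simply sits alongside those of compound 1 and compound 2.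

Compound 4 `C=C1C(=O)OC[C@H]1CCOC(=O)Nc1ccc(OC)cc1` follows from compound 1 by methoxy in place of iodo on an aromatic carbon. Within the data shown here, no measured step touches the group on that ring, and the only measured step is within the scatter, so nothing in the data calls for a step beyond the scatter in this assay in either direction. Compound 4 is therefore expected near compound 1, with a 1.0-fold higher number from compound 1 to compound 4 (0.01 log units; within the scatter). The estimate for compound 4 is 13000 nM, in the range 6000 nM to 28000 nM.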

Compound 4, half-maximal cytotoxic concentration: 12400 nM
The estimate for compound 4 lay 1.0-fold (0.02 log units) above the measured number; low and high end bracket the measured number.
By their numbers in this assay, from the lowest: compounds 4, 2, 1 and 3 (each within the scatter of the next).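

In this assay, within the data shown here, the earlier steps left the group on the aromatic ring untouched; here, a 1.0-fold lower number from compound 1 to compound 4 (0.01 log units; within the scatter), comes from changing that group, para to a large group. This place on the ring therefore takes methoxy in place of iodo, two heavy atoms for one and one hydrogen-bond acceptor where there was none, without a step beyond the scatter. Nothing available bears on why this exchange leaves the number within the scatter.

As far as these compounds go, whether the same holds for groups of another kind at this place, such as an amine, a carboxylic acid or a longer chain, stays open. Also open, from the compounds shown here alone, is whether methoxy in place of iodo gives a step of the same size in the configuration of compound 2.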